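The source may hold more compounds than are shown below. What is called first, only, known or untested is meant among the compounds shown, and "the series" means these compounds.

Measured so far: compound 1 `C[C@@H](Cn1ccc(-c2ccc(C#N)c(Cl)c2)n1)NC(=O)c1ccccc1F` with 1810 nM in a functional assay on LNCaP cells (Homo sapiens) for antiproliferative activity, read by CCK-8 assay, with a stated time of 6 days; on this read-out lower numbers stand for stronger inhibition and higher numbers for weaker inhibition; compound 2 `CC(=O)c1cccc(NC(=O)C(C)Cn2ccc(-c3ccc(C#N)c(Cl)c3)n2)c1` with 1540 nM in this assay.

Compound 1 holds the highest of the two numbers, but compound 2 sits within the scatter of it, so no order can be read between them. Compound 3 `C[C@@H](Cn1ccc(-c2ccc(C#N)c(Cl)c2)n1)Nc1ccccn1` is not yet measured. It differs from compound 1 in one place: pyridin-2-yl in place of (2-fluorophenyl)carbonyl on an amine nitrogen. Going by the values given here, no measured pair shows this change, so there is nothing to calibrate the step against. The expectation is a modest weakening in this assay, possibly no larger than the scatter, giving a step of a 1.4-fold higher number from compound 1 to compound 3 (0.16 log units; within the scatter). Compound 3 is accordingly estimated at 2600 nM, with a range from 800 nM to 8500 nM.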

Compound 3, half-maximal inhibitory concentration: 1110 nM
The estimate for compound 3 lay 2.3-fold (0.37 log units) above the measured number; measured number inside the range.
By their numbers in this assay, from the lowest: compounds 3, 2 and 1 (each within the scatter of the next).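

On the amine nitrogen, pyridin-2-yl stands in place of (2-fluorophenyl)carbonyl in this assay with a 1.6-fold lower number from compound 1 to compound 3 (0.21 log units; within the scatter). For this one pair, the carbonyl and the fluorinated benzene ring are therefore not needed to keep the number in the range of compound 1. Nothing measured bears on why the two groups read alike.

Still open, on these data alone, is whether a group without an aromatic ring, such as acetyl or a longer alkyl chain, holds this range on the same nitrogen. A carboxylic acid on the pyridin-2-yl ring is equally untested by the compounds shown.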